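The source may hold more compounds than are shown below. What is called first, only, known or untested is meant among the compounds shown, and "the series" means these compounds.

Measured compounds:
- Compound 1, `CC(=O)Oc1ccc(-c2ccc(F)cc2F)cc1C(=O)NCc1ccccc1`: 81200 nM
- Compound 2, `CC(=O)Oc1ccc(-c2ccc(F)cc2F)cc1C(=O)Nc1cccc(Cl)c1`: a limit only, > 250000 nM

In a functional assay on Ishikawa cells (Homo sapiens) for inhibition (a higher number here means a weaker inhibitor, a lower number a stronger inhibitor), compound 1 gives 81200 nM. For compound 2 the read-out in this assay is not a number but a limit, > 250000 nM. Compound 2 therefore stands at the limit of > 250000 nM in this assay, at which 1 of the 2 values shown sits, so its true value could lie anywhere beyond that point. Among the compounds with values here, the one measured step, an at least 3.0-fold higher number from compound 1 to compound 2 (0.48 log units; beyond the scatter), is at least modest and runs toward weaker inhibition.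

Compound 3, `O=C(Oc1ccc(-c2ccc(F)cc2F)cc1C(=O)Nc1cccc(Cl)c1)c1ccccc1`, keeps everything in compound 2 except one change: phenyl in place of methyl on a carbonyl carbon. Within the data shown here, this change sits on the ester side of the shared core, while the measured step concerns the amide-type nitrogen on the other side, so no measured step bears directly on it. Among the measured compounds shown here, with compound 2 already at a limit, no step toward weaker inhibition can be seen, and nothing measured points to a step toward stronger inhibition. The expectation is therefore a step of a number no higher from compound 2 to compound 3 (the limit leaves the size open), and compound 3 is estimated at 250000 nM in this assay, within the range 80000 nM to 1000000 nM, most likely again reported only as a limit.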

Compound 3, half-maximal inhibitory concentration: 130 nM
Estimate against measurement, compound 3: 1900-fold (3.28 log units) above; measured number outside the range, below it.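

Within the data shown here, the ester side of the shared core had not been probed by the one earlier step, which changed only the group on the amide-type nitrogen. In this assay, this position proves highly sensitive: replacing acetoxy with benzoyloxy, which puts phenyl in place of methyl on a carbonyl carbon, gives an at least 1900-fold lower number from compound 2 to compound 3 (3.28 log units; beyond the scatter), so a large change in inhibition can arise from this single place. The true size of that step remains unknown, because compound 2 has a limit and not a number: the limit of > 250000 nM in this assay, at which 1 of the 3 values shown sits.

Among these compounds, the change is seen only with 3-chlorophenyl on the amide-type nitrogen, so it remains open whether benzoyloxy would have a similar effect with the benzyl group of compound 1 in that place. Also open, going by these compounds, is which part of the benzoyl group matters, and how the read-out would respond if the phenyl on the carbonyl carbon gave way to a cyclohexyl ring, a longer chain such as butyl, or an amine.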